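The source may report more compounds than this note shows. Statements on the series, on what has been measured and on what is new or still open speak of the compounds shown alone.

Compound 2 `CCc1ccc(-c2c(-c3nn(C)c4ncnc(N5CCCC5)c34)cnn2C)cc1` stands highest of the two plain numbers in an ADME assay on microsomes from liver (Homo sapiens) for metabolic stability (on this read-out lower numbers stand for slow clearance and higher numbers for fast clearance), where compound 2 gives 200 mL/min/kg. Among the measured compounds shown here, compound 1 `CCc1ccc(-c2c(-c3nn(C)c4ncnc(N5CCN(C)CC5)c34)cnn2C)cc1` gives 60 mL/min/kg in this assay, and the only measured step that bears here is a 3.3-fold higher number from compound 1 to compound 2 (0.52 log units; beyond the scatter), a swap of one saturated ring amine for another. Compound 3 `CCCOc1cncc2nnc(-c3cnn(C)c3-c3ccc(C(F)(F)F)cc3)n12` gives only a limit in this assay, namely > 300 mL/min/kg; this is the limit of > 300 mL/min/kg in this assay, at which 1 of the 3 values shown sits. Compound 4 `CCc1ccc(-c2c(-c3nn(C)c4ncnc(N5CC(NC(=O)OC)C5)c34)cnn2C)cc1` differs from compound 2 by 3-((methoxycarbonyl)amino)azetidin-1-yl in place of pyrrolidin-1-yl on an aromatic carbon. Because a 3.3-fold higher number from compound 1 to compound 2 (0.52 log units; beyond the scatter) accompanied the earlier ring exchange, a step of similar size is expected for compound 4, this time downward, since the new group brings 1 hydrogen-bond donor and 3 hydrogen-bond acceptors. Compound 4 is expected near 80 mL/min/kg, within 30 mL/min/kg to 200 mL/min/kg. The expected change is a 2.5-fold lower number from compound 2 to compound 4 (0.40 log units; beyond the scatter).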

Compound 4, clearance: 42 mL/min/kg
The estimate for compound 4 lay 1.9-fold (0.28 log units) above the measured number; measured number inside the range.
By their numbers in this assay, from the lowest: compounds 4 and 1 (each within the scatter of the next); then compound 2. At a limit, above all of these: compound 3.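

At this aromatic carbon, 3-((methoxycarbonyl)amino)azetidin-1-yl in place of pyrrolidin-1-yl gives a 4.8-fold lower number from compound 2 to compound 4 (0.68 log units; beyond the scatter) in this assay, so a group with more heavy atoms here need not mean faster clearance. Set against 4-methylpiperazin-1-yl, the same group gives a 1.4-fold lower number from compound 1 to compound 4 (0.15 log units; within the scatter) and so no real difference, which leaves pyrrolidin-1-yl as the one group of these three with the faster clearance. Nothing measured here gives a reason for these steps. Still open, going by these compounds, is whether the four-membered ring or its side chain matters: a plain azetidin-1-yl would separate the two.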